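A few compounds are considered here, and "the series" means these few. Any claim that something is new, unique, unknown or untested is made for them only; others in the source may bear on it.

Compound 1 `O=C(CC1CCCCCC1)N1CCC(c2nc(-c3ccc4ccccc4n3)no2)CC1` gives 840 nM
Compound 2 `O=C(Nc1cccc2cccnc12)N1CCC(c2nc(-c3ccc4ccccc4n3)no2)CC1` gives 1400 nM

Both values come from a functional assay on Shh Light II cells (Mus musculus) for inhibition, read by a luciferase reporter; on this read-out lower numbers stand for stronger inhibition and higher numbers for weaker inhibition. Compound 2 stands within the usual scatter of compound 1 (a 1.7-fold higher number from compound 1 to compound 2 (0.22 log units; within the scatter)), so the two cannot be told apart on these numbers. Compound 3 `COc1ccccc1OC(=O)N1CCC(c2nc(-c3ccc4ccccc4n3)no2)CC1` has not yet been measured. It keeps the shared core and swaps one group (2-methoxyphenoxy in place of (quinolin-8-yl)amino on a carbonyl carbon), with 2-methoxyphenoxy in place of (quinolin-8-yl)amino on a carbonyl carbon. Going by the values given here, only one measured step bears on this. That same carbonyl carbon carried cycloheptylmethyl in one compound and (quinolin-8-yl)amino in the other, and the step stayed within the scatter (a 1.7-fold higher number from compound 1 to compound 2 (0.22 log units; within the scatter)). One step is thin evidence, and it says nothing about a phenoxy group, so no step beyond the scatter is expected in this assay and no direction can be favoured. The expected change is small (a 1.2-fold lower number from compound 2 to compound 3 (0.07 log units; within the scatter)). For compound 3 the estimated value is 1200 nM, with an expected range of 400 nM to 3500 nM.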

Compound 3, half-maximal inhibitory concentration: 250 nM
Estimate against measurement, compound 3: 4.8-fold (0.68 log units) above; the measured number lies below the stated range.
By their numbers in this assay, from the lowest: compound 3; then compounds 1 and 2 (each within the scatter of the next).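

The group on this carbonyl carbon clearly matters in this assay: 2-methoxyphenoxy gives a 5.6-fold lower number from compound 2 to compound 3 (0.75 log units; beyond the scatter) and also a 3.4-fold lower number from compound 1 to compound 3 (0.53 log units; beyond the scatter) even though the two earlier groups could not be told apart. The new group therefore stands apart from both an amino-linked and a carbon-linked group, so the position is not indifferent to what it carries. Nothing shown here gives a cause for this difference.

Still open, as far as these compounds go, is which part of 2-methoxyphenoxy carries the gain, as the whole group changes at once. A plain phenoxy group on the same carbonyl carbon would test the methoxy, and 2-methoxyphenylamino would test the oxygen that links the ring to the carbonyl.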